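Amide swaps on a shared bis-sulfonamide core, all unreadable

A few compounds are considered here, and "the series" means these few. Any claim that something is new, unique, unknown or untested is made for them only; others in the source may bear on it.

Compound 3, `CCN(CC)S(=O)(=O)c1ccc(S(=O)(=O)N2CCC[C@@H](C(=O)N3CCC(C(F)(F)F)CC3)C2)cc1`, is the starting point. In a functional assay on MIA PaCa-2 cells (Homo sapiens) for inhibition, read by MTT assay, with a stated time of 3 days (a lower number here means a stronger inhibitor, a higher number a weaker inhibitor), compound 3 gives > 10000 nM, which is a limit of the assay and not a number. Two related compounds share its core. Compound 1, `CCN(CC)S(=O)(=O)c1ccc(S(=O)(=O)N2CCC[C@@H](C(=O)N3CCOCC3)C2)cc1`, carries a morpholin-4-yl on the carbonyl carbon; in this assay compound 1 gives > 10000 nM, again a limit rather than a number. Compound 2, `CCN(CC)S(=O)(=O)c1ccc(S(=O)(=O)N2CCC[C@@H](C(=O)NC3CCOCC3)C2)cc1`, carries an (oxan-4-yl)amino at the same carbonyl carbon; in this assay compound 2 gives > 10000 nM, also a limit. The steps among these three, a step that the two limits leave unreadable from compound 1 to compound 2, a step that the two limits leave unreadable from compound 1 to compound 3 and a step that the two limits leave unreadable from compound 2 to compound 3, cannot be sized because of the limit of > 10000 nM in this assay, at which 3 of the 3 values shown sit. Compound 4, `CCN(CC)S(=O)(=O)c1ccc(S(=O)(=O)N2CCC[C@@H](C(=O)N[C@@H]3CCOC3)C2)cc1`, has not yet been measured. It differs from compound 3 by (oxolan-3-yl)amino in place of 4-(trifluoromethyl)piperidin-1-yl on a carbonyl carbon. The measured steps bear on this change only in one way: three different groups on the carbonyl carbon all leave the value at the limit in this assay, and none of the steps can be read in either direction. Going by the values given here, the new group is a fourth variation at the same place, with no measured step showing what it does. Compound 4 is therefore expected to give 15000 nM in this assay, with a range from 5000 nM to 50000 nM. The step from compound 3 to compound 4 is estimated as a step that the limit leaves unreadable from compound 3 to compound 4, meaning no change beyond the scatter is expected.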

Compound 4, half-maximal inhibitory concentration: > 10000 nM
Compound 4: no number, only a limit; the forecaster's own chance of this, stated with the estimate: 85%; the middle value is on the limit's open side.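

The steps from compound 1, compound 2 and compound 3 to compound 4 cannot be read, because these compounds all stop at the same assay limit, which is not a number: the limit of > 10000 nM in this assay, at which 4 of the 4 values shown sit. The compounds shown leave open how far apart they truly lie in this assay, and whether any group on the carbonyl carbon gives a measurable value.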